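This account rests on a few compounds, and the source may have more. Where it says the series, first, only, none or still open, it means among the compounds named here.

For the measured compounds named here, compound 3, with the structure `Cc1ccc(C(CCN(C)C)NC(=O)/C=C/c2ccccc2)cc1`, stands lowest of the three compounds measured so far in a functional assay on NIH3T3 cells for agonist activity at Urotensin-2 receptor (Homo sapiens), with a stated time of 5 days (a lower number here means a smaller maximal response, a higher number a larger maximal response), where compound 3 gives 97%. The other two share a chloro-bearing ring instead of its methyl-bearing one: compound 1, `CN(C)CCC(NC(=O)C#Cc1ccccc1)c1ccc(Cl)cc1`, gives 124% in this assay, and compound 2, `CN(C)CCC(NC(=O)CCc1ccccc1)c1ccc(Cl)cc1`, gives 139%. Both of these lie beyond the scatter above compound 3.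

Compound 4, `CN(C)CCC(NC(=O)/C=C/c1ccccc1)c1ccc(Cl)cc1`, is the unmeasured compound. It differs from compound 3 in one place: chloro in place of methyl on an aromatic carbon. Otherwise compound 4 matches compound 3, so it combines the chloro-bearing ring of compounds 1 and 2 with the rest of compound 3.

Going by the values given here, the only measured step, a number 15 percentage points higher from compound 1 to compound 2 (beyond the scatter), changes the group on the carbonyl carbon and leaves the ring untouched, so it does not describe the chloro-for-methyl change. What remains is that the two measured compounds carrying chloro both sit above compound 3, and the gap between compound 3 and compounds 1 and 2 is the only basis for an estimate. On that basis a modest rise is expected for compound 4, estimated as the step of a number 18 percentage points higher from compound 3 to compound 4 (beyond the scatter). Compound 4 is therefore expected to give about 115% in this assay, within a range from 90% to 145%.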

Compound 4, largest response reached (reported as efficacy), in percent of the reference or control that the assay uses: 128%
Compound 4: the middle estimate sits 13 percentage points below what was measured; the measured number falls inside the stated range.
By their numbers in this assay, from the lowest: compound 3; then compounds 1 and 4 (each within the scatter of the next); then compound 2.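

Holding the rest of the structure fixed, the change from 4-methylphenyl to 4-chlorophenyl gives the first direct reading of this ring position in this assay, and it is a large step: a number 31 percentage points higher from compound 3 to compound 4 (beyond the scatter). With chloro in place, the group on the carbonyl carbon can now be compared across all three options: a number 11 percentage points lower from compound 2 to compound 4 (beyond the scatter) and a number 4 percentage points higher from compound 1 to compound 4 (within the scatter), so 2-phenylethenyl differs from phenethyl in this series, but cannot be told apart from 2-phenylethynyl. No outside measurement is available to explain why exchanging methyl for chloro changes the maximal response by this amount.

Only methyl and chloro appear at this ring position, so the compounds shown leave open what a fluoro group, a methoxy group or a bare phenyl ring would do there, and whether the same step would appear with phenethyl or 2-phenylethynyl on the carbonyl carbon. From the compounds shown here alone, the dimethylamino end and its chain are also the same throughout, so the effect of a pyrrolidine, a primary amine or a longer chain remains unknown.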